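Inverting One Ring Stereocentre in a Hydroxylated Lactone

A few compounds are considered here, and "the series" means these few. Any claim that something is new, unique, unknown or untested is made for them only; others in the source may bear on it.

Of the compounds shown here, three have been measured in a functional assay on A2780 ADR cells (Homo sapiens) for cytotoxicity, read by MTT assay, with a stated time of 24 h; on this read-out lower numbers stand for stronger inhibition and higher numbers for weaker inhibition. Compound 1, `CCCCC[C@@H](CCC[C@H]1CC=CC(=O)O1)OC`, gives 9000 nM. Its mirror image, compound 3, `CCCCC[C@H](CCC[C@@H]1CC=CC(=O)O1)OC`, gives 20500 nM. Compound 2, `CCCCC[C@H](C[C@@H](O)C[C@@H]1CC=CC(=O)O1)OC`, which carries an extra hydroxy on the chain, gives 91500 nM, the highest of the three numbers: compound 3 sits nearest, and compound 1 furthest.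

Two steps connect them. For the measured compounds named here, there is a 2.3-fold higher number from compound 1 to compound 3 (0.36 log units; beyond the scatter), and the only change behind it is the fact that compounds 1 and 3 differ only in the configuration as drawn. There is also a 4.5-fold lower number from compound 2 to compound 3 (0.65 log units; beyond the scatter), where the hydroxy is replaced by hydrogen.

Compound 4, `CCCCC[C@H](C[C@@H](O)C[C@H]1CC=CC(=O)O1)OC`, is the next compound to be measured. Its relation to compound 2 is the two compounds have the same atoms and bonds and differ only in configuration as drawn: 1 of 3 stereo elements differ; a stereocentre at a saturated ring carbon is drawn S in compound 2 and R in compound 4. Going by the values given here, only the step from compound 1 to compound 3 speaks to a change of configuration alone, and there all stereocentres were inverted together; here a single ring stereocentre turns while the rest of the molecule is unchanged, so a shift of similar or smaller size is expected, without a clear direction. Because a 2.3-fold higher number from compound 1 to compound 3 (0.36 log units; beyond the scatter) was modest, the expected step is a 1.5-fold lower number from compound 2 to compound 4 (0.18 log units; within the scatter), and compound 4 is estimated at 60000 nM, within a range from 20000 nM to 180000 nM.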

Compound 4, half-maximal inhibitory concentration: 18100 nM
The estimate for compound 4 lay 3.3-fold (0.52 log units) above the measured number; measured number below the stated range.
By their numbers in this assay, from the lowest: compounds 1, 4 and 3 (each within the scatter of the next, the first and the last beyond it); then compound 2.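

Compound 4 isolates a single stereocentre: in this assay, turning only the saturated ring carbon gives a 5.1-fold lower number from compound 2 to compound 4 (0.70 log units; beyond the scatter), a step beyond the scatter. The earlier mirror-image pair, with a 2.3-fold higher number from compound 1 to compound 3 (0.36 log units; beyond the scatter), inverted every stereocentre at once and could not show which one mattered, whereas this shift can be assigned to the ring carbon alone because nothing else changes: the fact that compounds 2 and 4 differ only in the configuration as drawn. Compound 2 now also has two separate single changes that lower its number, since replacing the hydroxy by hydrogen gave a 4.5-fold lower number from compound 2 to compound 3 (0.65 log units; beyond the scatter), so its high number in this assay can be brought down from either place.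

As far as these compounds go, it remains open whether turning the carbon that carries the hydroxy, or the chain carbon that carries the methoxy, would on its own move the number in the same way, and whether the ring stereocentre matters as much without the hydroxy. Also open, from the compounds shown here alone, is how an amine in place of the hydroxy, or a longer chain, would read on this shared core.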